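Swapping a Bromophenyl for a Nitrophenyl on the Shared Core

A few compounds are considered here, and "the series" means these few. Any claim that something is new, unique, unknown or untested is made for them only; others in the source may bear on it.

Of the compounds shown here, three built on one shared core have been tested in a functional assay on HT-29 cells (Homo sapiens) for cytotoxicity, read by MTT assay, with a stated time of 72 h; on this read-out higher numbers stand for weaker inhibition and lower numbers for stronger inhibition. Compound 1 `COc1cc2c(Oc3ccc(NC(=O)c4nn(-c5cccc(F)c5)c(=O)c5ccccc45)cc3F)ccnc2cc1OCCCN1CCCC1` gives 460 nM, compound 2 `COc1cc2c(Oc3ccc(NC(=O)c4nn(-c5ccccc5F)c(=O)c5ccccc45)cc3F)ccnc2cc1OCCCN1CCCC1` gives 400 nM, and compound 3 `COc1cc2c(Oc3ccc(NC(=O)c4nn(-c5ccccc5Br)c(=O)c5ccccc45)cc3F)ccnc2cc1OCCCN1CCCC1` gives 850 nM, the highest of the three numbers shown. Compound 4 `COc1cc2c(Oc3ccc(NC(=O)c4nn(-c5ccc([N+](=O)[O-])cc5)c(=O)c5ccccc45)cc3F)ccnc2cc1OCCCN1CCCC1` carries the change (4-nitrophenyl in place of 2-bromophenyl on an aromatic nitrogen). The steps measured so far all concern halogens on that same phenyl: a 1.2-fold lower number from compound 1 to compound 2 (0.06 log units; within the scatter), a 1.8-fold higher number from compound 1 to compound 3 (0.27 log units; within the scatter) and a 2.1-fold higher number from compound 2 to compound 3 (0.33 log units; beyond the scatter). None is larger than modest, and none involves a nitro group, so their bearing on compound 4 is loose. A step of about a 1.5-fold lower number from compound 3 to compound 4 (0.19 log units; within the scatter) is expected, leaning toward a somewhat lower number. Compound 4 is therefore estimated at 550 nM, within a range from 200 nM to 1500 nM.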

Compound 4, half-maximal inhibitory concentration: 1760 nM
Compound 4: the middle estimate sits 3.2-fold (0.51 log units) below what was measured; the measured number lies above the stated range.
By their numbers in this assay, from the lowest: compounds 2, 1 and 3 (each within the scatter of the next, the first and the last beyond it); then compound 4.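

In this assay the 4-nitrophenyl group on the aromatic nitrogen gives the weakest compound shown, with a 2.1-fold higher number from compound 3 to compound 4 (0.32 log units; beyond the scatter) and a 4.4-fold higher number from compound 2 to compound 4 (0.64 log units; beyond the scatter) and a 3.8-fold higher number from compound 1 to compound 4 (0.58 log units; beyond the scatter). So this position responds to more than the halogen swaps revealed, as this change moves the number further than any of them. Nothing measured here gives a reason for the shift. Still open, as far as these compounds go, is whether the nitro group itself or its place on the phenyl matters more. Also open, from the compounds shown here alone, is how an amine or a carboxylic acid on that phenyl would read.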